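A few compounds are considered here, and "the series" means these few. Any claim that something is new, unique, unknown or untested is made for them only; others in the source may bear on it.

Compound 1 `Nc1cc(N)c2nc(-c3ccccc3)c(Oc3ccc(Cl)c(Cl)c3)nc2c1` and compound 2 `Nc1cc(N)c2nc(-c3ccccc3)c(NCc3ccc(F)cc3)nc2c1` share one core and differ in a single group on it. In a functional assay on PC-3 cells (Homo sapiens) for inhibition, read by sulforhodamine B assay, with a stated time of 48 h (on this read-out lower numbers stand for stronger inhibition of growth and higher numbers for weaker inhibition of growth), compound 1 gives 14500 nM, and in this assay compound 2 gives 15500 nM. Among the compounds with values here, the one recorded step, a 1.1-fold higher number from compound 1 to compound 2 (0.03 log units; within the scatter), lies within the scatter, so compound 2 stands within the scatter of compound 1, the only other number available. Compound 3 `Nc1cc(N)c2nc(-c3ccccc3)c(Sc3ccc(Cl)c(Cl)c3)nc2c1` is not yet measured; it carries (3,4-dichlorophenyl)sulfanyl in place of (4-fluorobenzyl)amino on an aromatic carbon. Compound 3 also differs from compound 1 only in that a (3,4-dichlorophenyl)sulfanyl group replaces the 3,4-dichlorophenoxy group. Within the data shown here, the only step bearing on this exchange, a 1.1-fold higher number from compound 1 to compound 2 (0.03 log units; within the scatter), was within the scatter, so no step beyond the scatter is expected for compound 3 in this assay in either direction. The step expected from compound 2 to compound 3 is a 1.1-fold lower number from compound 2 to compound 3 (0.04 log units; within the scatter). For compound 3 the estimate is 14000 nM, with a range from 5000 nM to 40000 nM.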

Compound 3, concentration for total growth inhibition: 15500 nM
Beside the measured number, compound 3's estimate is 1.1-fold (0.04 log units) below it; the measured number falls inside the stated range.
By their numbers in this assay, from the lowest: compounds 1, 2 and 3 (each within the scatter of the next).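

In this assay, replacing (4-fluorobenzyl)amino with (3,4-dichlorophenyl)sulfanyl gives no change at the digits printed from compound 2 to compound 3 (within the scatter), although the change goes from 1 hydrogen-bond donor to 0 hydrogen-bond donors, and replacing 3,4-dichlorophenoxy with (3,4-dichlorophenyl)sulfanyl gives a 1.1-fold higher number from compound 1 to compound 3 (0.03 log units; within the scatter). All three groups on this aromatic carbon, ortho to a phenyl group, therefore read alike, and no exchange among them yields a step beyond the scatter. No available evidence bears on this result.

As far as these compounds go, whether a small group such as an amine or a carboxylic acid on this carbon would give a step beyond the scatter remains open. Also open, from the compounds shown here alone, is whether a longer chain in place of these groups, each of 9 heavy atoms and carrying one aromatic ring, would do so.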